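The source may report more compounds than this note shows. Statements on the series, on what has been measured and on what is new or still open speak of the compounds shown alone.

Measured compounds, all in a functional assay on A549 cells (Homo sapiens) for cytotoxicity, read by MTT assay, with a stated time of 72 h; on this read-out lower numbers stand for stronger inhibition and higher numbers for weaker inhibition:
- compound 1, `O=S(=O)(c1ccccc1)c1nc2ccccc2nc1Nc1ccccc1`, gives 26300 nM
- compound 2, `Nc1ccc(Nc2nc3ccccc3nc2S(=O)(=O)c2ccccc2)cc1`, gives 12900 nM
- compound 3, `Cc1ccc(S(=O)(=O)c2nc3ccccc3nc2Nc2ccccc2)cc1`, gives 12500 nM

Compound 3 has the lowest number of the three. Its number and that of compound 2 lie within the scatter of each other, so the two cannot be ranked; compound 1 stands apart, as the step of a 2.1-fold lower number from compound 1 to compound 3 (0.32 log units; beyond the scatter) shows.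

Compound 4, `COc1cc(Nc2nc3ccccc3nc2S(=O)(=O)c2ccc(C)cc2)cc(OC)c1`, has not been measured. It differs from compound 3 in one place: 3,5-dimethoxyphenyl in place of phenyl on a nitrogen on an aromatic ring. Two measured steps help. The step of a 2.0-fold lower number from compound 1 to compound 2 (0.31 log units; beyond the scatter) changed the same phenyl on the nitrogen by a small addition and lowered the number modestly. The step of a 2.1-fold lower number from compound 1 to compound 3 (0.32 log units; beyond the scatter) changed the other phenyl and lowered the number by a similar modest amount. Among the measured compounds shown here, neither step involves methoxy groups, and no measured pair shows two groups added at once, so the expectation rests on these small additions only.

A modest lowering, or no change beyond the scatter, is therefore expected in this assay for compound 4, an estimated step of a 1.6-fold lower number from compound 3 to compound 4 (0.19 log units; within the scatter). For compound 4 the estimate is 8000 nM, with a range from 3000 nM to 22000 nM.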

Compound 4, half-maximal inhibitory concentration: 8060 nM
Estimate against measurement, compound 4: 1.0-fold (0.00 log units) below; the range from low to high includes it.
By their numbers in this assay, from the lowest: compounds 4, 3 and 2 (each within the scatter of the next); then compound 1.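

In this assay, replacing phenyl with 3,5-dimethoxyphenyl on a nitrogen on an aromatic ring gives a 1.6-fold lower number from compound 3 to compound 4 (0.19 log units; within the scatter), so this larger group, which brings two hydrogen-bond acceptors, produces no change that can be told from the scatter. The earlier compounds shown here showed only a small addition on this phenyl, the amino group in a 2.0-fold lower number from compound 1 to compound 2 (0.31 log units; beyond the scatter), on a core without the methyl group, and that step was modest but beyond the scatter. The new step shows that this position, with the methyl group present, can carry a much bigger group while the number stays within the scatter of compound 3, though nothing available gives a cause for this.

The compounds shown leave open what a single methoxy group would do here, and whether a carboxylic acid or a morpholine on this phenyl, or a longer chain in its place, would move the number beyond the scatter. They also leave open whether 3,5-dimethoxyphenyl would give the same reading on the core of compound 1, which lacks the methyl group.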